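The source may hold more compounds than are shown below. What is called first, only, known or untested is meant among the compounds shown, and "the series" means these compounds.

Compound 1 `CC(C)c1ccc(-c2nc(SCc3cn(CC(=O)NC(=O)Nc4ccccn4)nn3)nc(Nc3ccc(F)cc3)c2C#N)cc1` in a functional assay on MCF7 cells (Homo sapiens) for inhibition, read by MTT assay, with a stated time of 72 h; on this read-out lower numbers stand for stronger inhibition and higher numbers for weaker inhibition: > 64000 nM, a limit of the assay.
Compound 2 `CC(C)c1ccc(-c2nc(SCc3cn(CC(=O)NC(=O)Nc4ccccn4)nn3)nc(Nc3ccccc3)c2C#N)cc1` in this assay: > 64000 nM, a limit of the assay.

On the numbers shown, compound 2 stands at a limit: its value in this assay is not a number but the top of what the assay reports, and the one further value shown is a limit as well. The step that the two limits leave unreadable from compound 1 to compound 2, hydrogen in place of fluoro on an aromatic carbon, therefore cannot be read in size or in direction. For the measured compounds named here, the only evidence on the measured steps is the limit of > 64000 nM in this assay, at which 2 of the 2 values shown sit.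

Compound 3 `Cc1cccc(Nc2nc(SCc3cn(CC(=O)NC(=O)Nc4ccccn4)nn3)nc(-c3ccc(C(C)C)cc3)c2C#N)c1` differs from compound 2 by methyl in place of hydrogen on an aromatic carbon of a six-membered aromatic ring of carbon only, meta to a large group; cut one bond further out, anilino becomes (3-methylphenyl)amino. No measured step bears on this change, and the one step shown is unreadable. With nothing pointing to a gain, compound 3 is expected to stay at the limit, the expected step that the limit leaves unreadable from compound 2 to compound 3 being none that could be read. In this assay compound 3 is therefore estimated at 100000 nM, with a range from 30000 nM to 400000 nM, and most probably reported once more only as a limit.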

Compound 3, half-maximal inhibitory concentration: > 64000 nM
Compound 3: a limit, no number; the forecaster's own chance of this, stated with the estimate: 85%; the middle value is on the limit's open side.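

In this assay compound 3 gives > 64000 nM, a limit of the assay and not a number, so no new step can be read from compound 2 or compound 1 to compound 3. The compounds shown leave open how fluoro, hydrogen and methyl on this aromatic ring compare, and all that they show is this: the limit of > 64000 nM in this assay, at which 3 of the 3 values shown sit.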